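One Trifluoromethyl Group on the Phenyl of Compound 2

A few compounds are considered here, and "the series" means these few. Any claim that something is new, unique, unknown or untested is made for them only; others in the source may bear on it.

In a functional assay on NCI-H661 cells (Homo sapiens) for antiproliferative activity, read by MTT assay, with a stated time of 72 h (a higher number here means a weaker inhibitor, a lower number a stronger inhibitor), compound 1 `COc1ccc(-c2noc(CCCCCCC(=O)NO)n2)cc1` gives 20400 nM while compound 2 `Nc1ccccc1NC(=O)CCCCCCc1nc(-c2ccccc2)no1` gives 960 nM as the lower of the two numbers, a gap beyond the scatter. Compound 3 `Nc1ccccc1NC(=O)CCCCCCc1nc(-c2ccc(C(F)(F)F)cc2)no1` carries trifluoromethyl in place of hydrogen on an aromatic carbon of compound 2 (trifluoromethyl in place of hydrogen on an aromatic carbon), para to a large group. Among the compounds with values here, no pair of measured compounds shows this change, so the expectation rests on the structural change alone. No shift beyond the scatter is expected in this assay and the estimated step is a 1.2-fold lower number from compound 2 to compound 3 (0.08 log units; within the scatter) with no firm direction. Compound 3 is estimated at 800 nM with 300 nM to 2500 nM as the expected range.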

Compound 3, half-maximal inhibitory concentration: 29800 nM
Compound 3: middle estimate off by 37-fold (1.57 log units), on the low side; the whole stated range lies below it.
By their numbers in this assay, from the lowest: compound 2; then compounds 1 and 3 (each within the scatter of the next).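

In this assay, the phenyl of compound 2 proves sensitive to substitution: trifluoromethyl in place of hydrogen on an aromatic carbon, para to a large group, gives a 31-fold higher number from compound 2 to compound 3 (1.49 log units; beyond the scatter) and thus removes most of the activity of compound 2. Within the data shown here, no earlier pair had tested this position, and this single change is enough to make a large difference. Nothing shown accounts for the loss. As far as these compounds go, whether a chlorine, a methyl, an amine or a carboxylic acid on the same carbon would be tolerated remains open, as does whether trifluoromethyl would cost as much elsewhere on the ring.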